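This account rests on a few compounds, and the source may have more. Where it says the series, first, only, none or still open, it means among the compounds named here.

Working notes on the series. In an ADME assay on Akata cells (Homo sapiens) for cytotoxicity (on this read-out higher numbers stand for lower toxicity in this test and lower numbers for higher toxicity in this test), compound 1 (`Nc1nc2c(ncn2/C=C2\C[C@@H]2[C@H](O)CO)c(=O)[nH]1`) gives 67000 nM and compound 3 (`Nc1nc2c(ncn2/C=C2/C[C@@H]2[C@@H](O)CO)c(=O)[nH]1`) gives 56000 nM. Compound 2 (`Nc1ncnc2c1ncn2/C=C1/C[C@H]1[C@H](O)CO`) gives 93500 nM, which lies within the scatter of both of the other values.

The next comparison is with compound 4 (`Nc1ncnc2c1ncn2/C=C1\C[C@@H]1[C@H](O)CO`), still unmeasured in this assay. The change from compound 2 is the two compounds have the same atoms and bonds and differ only in configuration as drawn: 2 of 3 stereo elements differ; a stereocentre at a saturated ring carbon is drawn R in compound 2 and S in compound 4; a double bond is drawn Z in compound 2 and E in compound 4. No group leaves or enters, so only the drawn configuration is at issue.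

Within the data shown here, one measured step bears on this: a 1.2-fold lower number from compound 1 to compound 3 (0.08 log units; within the scatter). It rests on (the fact that compounds 1 and 3 differ only in the configuration as drawn), and it too involves 2 of 3 stereo elements, including a double bond drawn E in compound 1 and Z in compound 3. Among the measured compounds shown here, its stereocentre, however, is at a saturated chain carbon, whereas the one that changes in compound 4 is at a saturated ring carbon. It is therefore only an indirect guide, and the effect of the ring stereocentre has not been measured in this series.

With that one step inside the scatter, no change beyond the scatter is expected in this assay. The expected step is a 1.1-fold lower number from compound 2 to compound 4 (0.04 log units; within the scatter), with no direction firmly implied. The estimated value for compound 4 is 85000 nM, with an expected range from 40000 nM to 180000 nM.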

Compound 4, half-maximal cytotoxic concentration: 57000 nM
Compound 4: the middle estimate sits 1.5-fold (0.17 log units) above what was measured, and the stated range covers the measured number.
By their numbers in this assay, from the lowest: compounds 3, 4, 1 and 2 (each within the scatter of the next).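

Among these compounds, the step of a 1.6-fold lower number from compound 2 to compound 4 (0.21 log units; within the scatter) is the first reading in this assay on the stereocentre at a saturated ring carbon, which stayed the same between compounds 1 and 3. Redrawing that ring stereocentre together with the double bond leaves the read-out within the scatter, just as redrawing the chain stereocentre together with the double bond did in the earlier step of a 1.2-fold lower number from compound 1 to compound 3 (0.08 log units; within the scatter). So across both pairs, two different combinations of stereo elements have now been changed without a step beyond the scatter, and this pair is a direct test of configuration, as no group leaves or enters: the fact that compounds 2 and 4 differ only in the configuration as drawn

On these data alone, the ring stereocentre and the double bond change together in this pair, so the contribution of each one alone remains open, and a small effect from one could be offset by the other. Also open, as far as these compounds go, is whether configuration would stay this unimportant in compounds carrying an amine or a carboxylic acid on the side chain, or a longer chain in its place.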